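Methoxycarbonyl swap in a series held at assay limits

The source may hold more compounds than are shown below. What is called first, only, known or untested is meant among the compounds shown, and "the series" means these compounds.

Of the compounds shown here, three on a shared core have been tested in a functional assay on HCT-116 cells (Homo sapiens) for cytotoxicity, read by MTT assay, with a stated time of 72 h; a lower number here means a stronger inhibitor, a higher number a weaker inhibitor: compound 1 `O=C(NCc1ccc(F)cc1)c1nc(Br)c2cccnc2c1NCCO`, compound 2 `NCCNc1c(C(=O)NCc2ccc(F)cc2)nc(Br)c2cccnc12` and compound 3 `CNCCCNc1c(C(=O)NCc2ccc(F)cc2)nc(Br)c2cccnc12`. Compound 1 gives > 20000 nM, which is a limit and not a number. Compound 2 gives > 20000 nM, also a limit. Compound 3 gives > 10000 nM, again a limit, so it has no measured number of its own.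

The next compound to be measured is compound 4 `COC(=O)CNc1c(C(=O)NCc2ccc(F)cc2)nc(Br)c2cccnc12`. The change is methoxycarbonyl in place of 2-(methylamino)ethyl on a saturated chain carbon bound to a nitrogen on an aromatic ring.

The measured steps that bear on this chain are a step that the two limits leave unreadable from compound 1 to compound 2, a step that the two limits leave unreadable from compound 1 to compound 3 and a step that the two limits leave unreadable from compound 2 to compound 3. None of them gives a size to carry over. The expectation rests on compound 3 at > 10000 nM, a limit, so no step beyond the usual scatter is expected in this assay, and no direction can be given. The estimated step is a step that the limit leaves unreadable from compound 3 to compound 4. For compound 4 the estimated value is 20000 nM, with an expected range from 10000 nM to 40000 nM, and a reported limit is the likely outcome.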

Compound 4, half-maximal inhibitory concentration: > 10000 nM
Compound 4: no number, only a limit; the forecaster's own chance of this, stated with the estimate: 80%; the middle value is on the limit's open side.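

In this assay compound 4 gives > 10000 nM, which is a limit and not a number. With limits on both sides, the steps from compound 1, compound 2 and compound 3 to compound 4 cannot be read. The compounds shown leave open whether any chain on the shared core gives a measurable half-maximal inhibitory concentration in this assay.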